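Swapping the Pyrimidine for a Phenyltetrazole in Compound 1

The source may hold more compounds than are shown below. What is called first, only, known or untested is meant among the compounds shown, and "the series" means these compounds.

Of the compounds shown here, three that share one core have been tested in a functional assay on C6 cells (Rattus norvegicus) for cytotoxicity, read by MTT assay, with a stated time of 24 h, tested at 6 ug/mL; a lower number here means a stronger effect, a higher number a weaker effect of the compound at the concentration tested. Compound 1 `O=C(CSc1ncccn1)N/N=c1/scc(-c2ccc(Br)cc2)n1-c1ccccc1` gives 76.4%. Compound 2 `COc1ccc(-c2cs/c(=N/NC(=O)CSc3ncccn3)n2-c2ccccc2)cc1` gives 89.6%, and compound 3 `Cc1ccc(-c2cs/c(=N/NC(=O)CSc3ncccn3)n2-c2ccccc2)cc1` gives 93.2%. Compound 1 thus shows the lowest number, and hence the strongest effect, of the three: the steps are a number 13.2 percentage points higher from compound 1 to compound 2 (beyond the scatter) and a number 16.8 percentage points higher from compound 1 to compound 3 (beyond the scatter), while between the other two there is a number 3.6 percentage points higher from compound 2 to compound 3 (within the scatter). Compound 4 `O=C(CSc1nnnn1-c1ccccc1)N/N=c1/scc(-c2ccc(Br)cc2)n1-c1ccccc1` differs from compound 1 at a different place: 1-phenyl-1H-tetrazol-5-yl in place of pyrimidin-2-yl on a sulfur. The measured steps all concern the group on the aromatic carbon and are modest; none of them touches the group on the sulfur, so they give no direct guide to this change. With nothing bearing on it, the expectation is a number close to that of compound 1, meaning a step of a number 0.6 percentage points higher from compound 1 to compound 4 (within the scatter) that stays within the scatter. Compound 4 is therefore estimated at 77%, with the value expected to fall between 62% and 92%.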

Compound 4, a percentage reported as activity, at one concentration (the size of the read-out at that concentration, not a potency): 61.8%
Compound 4: middle estimate off by 15.2 percentage points, on the high side; the whole stated range lies above it.
By their numbers in this assay, from the lowest: compound 4; then compound 1; then compounds 2 and 3 (each within the scatter of the next).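

In this assay, going by these compounds alone, putting 1-phenyl-1H-tetrazol-5-yl in place of pyrimidin-2-yl on the sulfur gives a number 14.6 percentage points lower from compound 1 to compound 4 (beyond the scatter), so this position, untouched by the earlier compounds, can also shift the read-out, here towards a stronger effect. The entering group brings a five-membered aromatic ring and a six-membered aromatic ring of carbon only, and this single step cannot separate what each of them contributes. Nothing available explains the shift.

On these data alone, it remains open whether the same exchange would act alike on compound 2 or compound 3, which carry methoxy and methyl on the aromatic carbon. Also open, as far as these compounds go, is how the read-out would respond to a simple ethyl chain or a chain ending in a carboxylic acid on the sulfur.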